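Working notes: from compound 2 to compound 3

This account rests on a few compounds, and the source may have more. Where it says the series, first, only, none or still open, it means among the compounds named here.

Going by the values given here, two measured compounds define the series so far. Compound 1 `CCc1nnc(NS(=O)(=O)c2ccc(NC(=O)Nc3ccc(C(F)(F)F)cc3)cc2)s1` gives 10000 nM in an assay on Sf9 cells for displacement of a labelled ligand from P2Y purinoceptor 1 (Homo sapiens); a higher number here means a weaker inhibitor, a lower number a stronger inhibitor. Compound 2 `Cc1noc(NS(=O)(=O)c2ccc(NC(=O)Nc3cccc(Cl)c3)cc2)c1C` reaches only a limit of the assay in this assay, namely >= 100000 nM, and so sits at the limit of >= 100000 nM in this assay, at which 1 of the 2 values shown sits. Among the compounds with values here, no step between measured compounds is recorded, so nothing sets the scale of a change here; the two values show only that compound 1 returned a number and compound 2 did not. Compound 3 `Cc1noc(NS(=O)(=O)c2ccc(NC(=O)Nc3cc(Cl)cc(Cl)c3)cc2)c1C` differs from compound 2 by chloro in place of hydrogen on an aromatic carbon. For a single chloro added to a ring already carrying one, the step of an at least 2.0-fold lower number from compound 2 to compound 3 (0.30 log units; that floor lies within the scatter) is expected to be modest, in the direction of a stronger inhibitor if anything, with a real chance that another limit is reported. Compound 3 is therefore estimated at 50000 nM, within 8000 nM to 200000 nM.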

Compound 3, inhibition constant: 27000 nM
Beside the measured number, compound 3's estimate is 1.9-fold (0.27 log units) above it; measured number inside the range.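

Going by these compounds alone, the change from 3-chlorophenyl to 3,5-dichlorophenyl gives the only step so far in this assay: an at least 3.7-fold lower number from compound 2 to compound 3 (0.56 log units; beyond the scatter). A chloro on this aromatic carbon, meta to a chloro group, therefore goes with a stronger inhibitor, and compound 3 returns a number on the shared core where compound 2 does not. The step fixes only a minimum size for the change, because compound 2 stands at a limit: the limit of >= 100000 nM in this assay, at which 1 of the 3 values shown sits.

From the compounds shown here alone, whether the gain belongs to chloro itself or would also come with fluoro, methyl, methoxy or trifluoromethyl on this carbon remains open. Compound 1 differs from compound 3 in more than one place, so the compounds shown do not separate the contribution of the ethyl-bearing ring from that of the aryl substitution.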